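This account rests on a few compounds, and the source may have more. Where it says the series, first, only, none or still open, it means among the compounds named here.

Values from an ADME assay on MT4 cells (Homo sapiens) for cytotoxicity, with a stated time of 5 days (on this read-out lower numbers stand for higher toxicity in this test and higher numbers for lower toxicity in this test), follow.

- Compound 1 `CC(C)(C)C#Cc1cc(N(C(=O)[C@H]2CC[C@H](C)CC2)[C@H]2CC[C@@H](Oc3ccc(=O)[nH]n3)CC2)c(C(=O)O)s1` gives > 20000 nM as a limit.
- Compound 2 `C[C@H]1CC[C@H](C(=O)N(c2cc(C#CC3(C(F)(F)F)CC3)sc2C(=O)O)[C@H]2CC[C@H](Oc3ccc(=O)[nH]n3)CC2)CC1` gives > 20000 nM as a limit.
- Compound 3 `CC(C)(C)C#Cc1cc(N(CCO)C(=O)[C@H]2CC[C@H](C)CC2)c(C(=O)O)s1` gives > 20000 nM as a limit.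

Compound 2 stands at a limit and not at a number. So do the other two measured compounds, and the whole set comes down to a single line (the limit of > 20000 nM in this assay, at which 3 of the 3 values shown sit). None of the three can therefore be ranked against another.

Compound 4 `CC(C)(C#Cc1cc(N(C(=O)[C@H]2CC[C@H](C)CC2)[C@H]2CC[C@H](Oc3ccc(=O)[nH]n3)CC2)c(C(=O)O)s1)C(F)(F)F` has not yet been measured. It differs from compound 2 in one place: on a triple-bonded carbon, 1-methyl-1-(trifluoromethyl)ethyl stands in place of 1-(trifluoromethyl)cyclopropyl 1-methyl-1-(trifluoromethyl)ethyl in place of 1-(trifluoromethyl)cyclopropyl on a triple-bonded carbon in this comparison. What leaves with the old group is its three-membered non-aromatic ring of carbon only, and the new group has no ring.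

Going by the values given here, no measured pair offers a step to lean on, so the expectation rests on compound 2 alone. Among the compounds with values here, a step beyond the usual scatter is not expected in this assay in either direction, since compound 2 gives > 20000 nM as a limit and only this one group differs. The most likely report is again a limit. The expected change is a number no higher from compound 2 to compound 4 (the limit leaves the size open) by this estimate. For compound 4 the estimated value is 20000 nM with an expected range from 12000 nM to 40000 nM in this test.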

Compound 4, half-maximal cytotoxic concentration: > 20000 nM
Compound 4: a limit, no number; the forecaster's own chance of this, stated with the estimate: 88%; the middle value sits exactly at the limit.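

In this assay compound 4 gives > 20000 nM, which is a limit and not a number. Going by these compounds alone, compound 2 also stands at a limit, and no step from compound 2 to compound 4 can be read. The compounds shown leave open at what concentration any of them harms these cells, and whether putting 1-methyl-1-(trifluoromethyl)ethyl in place of 1-(trifluoromethyl)cyclopropyl shifts that concentration.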